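Trimethoxyphenyl rearrangement on a thiazolidinedione-benzimidazole series

A few compounds are considered here, and "the series" means these few. Any claim that something is new, unique, unknown or untested is made for them only; others in the source may bear on it.

The study examines compound 1 `COc1cc(-c2nc3cc(/C=C4\SC(=O)N(CC(=O)N5CCOCC5)C4=O)ccc3[nH]2)cc(OC)c1OC`, compound 2 `COc1cc(OC)c(-c2nc3cc(/C=C4\SC(=O)N(CC(=O)N5CCOCC5)C4=O)ccc3[nH]2)cc1OC`, compound 3 `COc1cc(-c2nc3cc(/C=C4\SC(=O)N(Cc5cccc(C)c5)C4=O)ccc3[nH]2)cc(OC)c1OC` and the not yet measured compound 4 `COc1cc(OC)c(-c2nc3cc(/C=C4\SC(=O)N(Cc5cccc(C)c5)C4=O)ccc3[nH]2)cc1OC` in a functional assay on HeLa cells (Homo sapiens) for inhibition, read by MTT assay, with a stated time of 48 h; on this read-out lower numbers stand for stronger inhibition and higher numbers for weaker inhibition. Compound 1 gives 16300 nM, compound 2 gives 510 nM, and compound 3 gives 1440 nM. The two measured steps from compound 1 are both large: a 32-fold lower number from compound 1 to compound 2 (1.50 log units; beyond the scatter), and an 11-fold lower number from compound 1 to compound 3 (1.05 log units; beyond the scatter).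

Compound 4 differs from compound 3 as follows: 2,4,5-trimethoxyphenyl in place of 3,4,5-trimethoxyphenyl on an aromatic carbon. The same change, seen between measured compounds, is 2,4,5-trimethoxyphenyl in place of 3,4,5-trimethoxyphenyl on an aromatic carbon, and it gave a 32-fold lower number from compound 1 to compound 2 (1.50 log units; beyond the scatter). The cores on which it is made differ in this way: 3-methylphenyl in place of (morpholin-4-yl)carbonyl on a saturated chain carbon bound to an amide-type nitrogen in a ring. Since both place lines read the same word for word, the change from compound 3 to compound 4 is the same change as from compound 1 to compound 2.

Among the compounds with values here, a step of similar direction, though possibly smaller, is expected for compound 4 because of the single precedent a 32-fold lower number from compound 1 to compound 2 (1.50 log units; beyond the scatter), giving an estimated 18-fold lower number from compound 3 to compound 4 (1.26 log units; beyond the scatter). Compound 4 is therefore expected to give about 80 nM, between 20 nM and 400 nM, in this assay.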

Compound 4, half-maximal inhibitory concentration: 180 nM
The estimate for compound 4 lay 2.3-fold (0.35 log units) below the measured number; the range from low to high includes it.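

In this assay the move to 2,4,5-trimethoxyphenyl again lowers the number on the core of compound 3, with an 8.0-fold lower number from compound 3 to compound 4 (0.90 log units; beyond the scatter), so the direction of this change carries over from one core to the other. The size does not carry over, and the gap between the two steps is larger than scatter alone would give: the same change on two cores in this assay, a 32-fold lower number (1.50 log units; beyond the scatter) from compound 1 to compound 2 and an 8.0-fold lower number (0.90 log units; beyond the scatter) from compound 3 to compound 4, 4.0-fold (0.60 log units) apart, beyond the scatter of two such steps. The exchange of (morpholin-4-yl)carbonyl for 3-methylphenyl gives a 2.8-fold lower number from compound 2 to compound 4 (0.45 log units; beyond the scatter) and likewise keeps its direction but not its size, so two cores show neither a fixed size for either change nor a reason for the gap: the same change on two cores in this assay, an 11-fold lower number (1.05 log units; beyond the scatter) from compound 1 to compound 3 and a 2.8-fold lower number (0.45 log units; beyond the scatter) from compound 2 to compound 4, 4.0-fold (0.60 log units) apart, beyond the scatter of two such steps.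

The compounds shown leave open whether the gain from 2,4,5-trimethoxyphenyl persists when an amine, a carboxylic acid or a longer chain stands in the place of the 3-methylphenyl group. Within the data shown here, they also leave open how a phenyl ring with only two methoxy groups, or with a chloro group, would read in this assay.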